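Two aryl caps on a shared ketone-oxazole core

The compounds below may be only part of what the source reports. "The series", "measured", "known", "first", "only" and "open" are said of these compounds alone.

Compound 1 `O=C(CCCCC#Cc1cccc(C(F)(F)F)c1)c1ncc(-c2ccccn2)o1` gives 10 nM in an assay for inhibition of Fatty-acid amide hydrolase 1 (Rattus norvegicus); a lower number here means a stronger inhibitor, a higher number a weaker inhibitor. Compound 2 `O=C(CCCCCCc1cccc(Cl)c1Cl)c1ncc(-c2ccccn2)o1` gives 0.9 nM in this assay, the lowest of the two numbers, with compound 1 as its nearest neighbour beyond the scatter. Compound 3 `CSc1ccc(CCCCCCC(=O)c2ncc(-c3ccccn3)o2)cc1` differs from compound 2 in one place: 4-(methylsulfanyl)phenyl in place of 2,3-dichlorophenyl on a saturated chain carbon, six bonds along the chain from a carbonyl carbon. Going by the values given here, no measured pair shows this change, so the direction rests on expectation alone. Compound 3 is expected to move toward a higher number than compound 2, by a step of a 4.4-fold higher number from compound 2 to compound 3 (0.65 log units; beyond the scatter). The estimate for compound 3 is 4 nM, within 1 nM to 15 nM.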

Compound 3, inhibition constant: 2.5 nM
Estimate against measurement, compound 3: 1.6-fold (0.20 log units) above, and the stated range covers the measured number.
By their numbers in this assay, from the lowest: compound 2; then compound 3; then compound 1.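

Swapping 2,3-dichlorophenyl for 4-(methylsulfanyl)phenyl on a saturated chain carbon, six bonds along the chain from a carbonyl carbon, gives a 2.8-fold higher number from compound 2 to compound 3 (0.44 log units; beyond the scatter) in this assay. The step is modest but beyond the scatter, so this position tolerates a chlorine-free aryl group with a sulfur-bearing substituent, though the two groups are not equivalent here. Nothing measured here explains this step.

Going by these compounds, it remains open whether the shift follows the loss of the two chlorines or the arrival of the methylsulfanyl group. A plain phenyl or a 4-chlorophenyl group at this position would separate the two.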